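Swapping hydroxy for hexyl in a cell assay

The source may report more compounds than this note shows. Statements on the series, on what has been measured and on what is new or still open speak of the compounds shown alone.

- compound 1 `O=C(OCCCCCCCCO)OCCc1ccc(OCc2ccccc2)c(OCc2ccccc2)c1`: "not determined" (no result reported)
- compound 2 `O=C(OCCO)OCCc1ccc(O)c(O)c1`: "not determined" (no result reported)
- compound 3 `O=C(OCCOC(=O)OCCc1ccc(O)c(O)c1)OCCc1ccc(O)c(O)c1`: > 50000 nM

In an ADME assay on MRC5 cells (Homo sapiens) for inhibition, read by MTT assay, with a stated time of 72 h (a higher number here means a weaker inhibitor, a lower number a stronger inhibitor), compound 2 gives "not determined" (no result reported), so it offers no single number to start from. Only one entry in this small set carries a figure. Compound 3 gives > 50000 nM, and this is a limit, not a number.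

Compound 4 `CCCCCCCCOC(=O)OCCc1ccc(O)c(O)c1` has yet to be measured. The structural change is hexyl in place of hydroxy on a saturated chain carbon, two bonds along the chain from an oxygen next to a carbonyl group.

Among the compounds with values here, no measured pair shows what such a change does, so any expectation here is rough. A moderate move in this assay towards lower numbers, meaning stronger inhibition, is expected, somewhat beyond the usual scatter. The assay may still report only a limit. The estimated value for compound 4 is 30000 nM, with an expected range of 10000 nM to 80000 nM.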

Compound 4, half-maximal inhibitory concentration: 37900 nM
Beside the measured number, compound 4's estimate is 1.3-fold (0.10 log units) below it, within the range that was stated.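

Within the data shown here, compound 2 has no reported result in this assay, so no step to compound 4 can be read. What hexyl in place of hydroxy does to inhibition stays open, and compound 3 cannot settle it, as its entry is only a limit: the limit of > 50000 nM in this assay, at which 1 of the 4 values shown sits.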